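The source may report more compounds than this note shows. Statements on the series, on what has been measured and on what is new or still open speak of the compounds shown alone.

Of the compounds shown here, three built on one shared core have been tested in a functional assay on HepG2 cells (Homo sapiens) for cytotoxicity, read by MTT assay, with a stated time of 48 h; a higher number here means a weaker inhibitor, a lower number a stronger inhibitor. Compound 1 `COc1cc(-c2nnc3n2NC(c2cccs2)C(C(=O)c2ccccc2)S3)cc(OC)c1OC` carries a plain phenyl on the carbonyl carbon. In this assay compound 1 reaches only the limit of the assay, > 100000 nM, which is not a number. Compound 2 `COc1cc(-c2nnc3n2NC(c2cccs2)C(C(=O)c2ccc(F)cc2)S3)cc(OC)c1OC` carries a 4-fluorophenyl in the same place, and in this assay compound 2 gives 54200 nM. The change between them gave an at least 1.8-fold lower number from compound 1 to compound 2 (0.26 log units; that floor lies within the scatter). Compound 3 `COc1cc(C(=O)C2Sc3nnc(-c4cc(OC)c(OC)c(OC)c4)n3NC2c2cccs2)cc(OC)c1OC` carries a 3,4,5-trimethoxyphenyl on the carbonyl carbon. In this assay compound 3 sits at the limit of the assay, > 100000 nM, which is not a number. Compound 3 thus shares its place with compound 1, as the limit of > 100000 nM in this assay, at which 2 of the 3 values shown sit, records. The steps reaching compound 3 were an at least 1.8-fold higher number from compound 2 to compound 3 (0.26 log units; that floor lies within the scatter) and a step that the two limits leave unreadable from compound 1 to compound 3.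

Compound 4 `COc1ccc(C(=O)C2Sc3nnc(-c4cc(OC)c(OC)c(OC)c4)n3NC2c2cccs2)cc1` differs from compound 3 by 4-methoxyphenyl in place of 3,4,5-trimethoxyphenyl on a carbonyl carbon. This brings the compound back toward a single substituent on that ring, closer to compound 2, whose value of 54200 nM and the step of an at least 1.8-fold higher number from compound 2 to compound 3 (0.26 log units; that floor lies within the scatter) both point to little movement beyond the scatter. Compound 4 is therefore expected near 90000 nM, between 40000 nM and 250000 nM. That estimate means a step of an at least 1.1-fold lower number from compound 3 to compound 4 (0.04 log units; that floor lies within the scatter), expected to stay within the scatter.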

Compound 4, half-maximal inhibitory concentration: 68000 nM
Compound 4: middle estimate off by 1.3-fold (0.12 log units), on the high side, within the range that was stated.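

In this assay compound 4 gives a measured number with a methoxy on the ring at the carbonyl carbon, and the swap of fluoro for methoxy is a 1.3-fold higher number from compound 2 to compound 4 (0.10 log units; within the scatter) with no readable change at this position. The other two steps are an at least 1.4-fold lower number from compound 3 to compound 4 (0.16 log units; that floor lies within the scatter) and an at least 1.4-fold lower number from compound 1 to compound 4 (0.16 log units; that floor lies within the scatter) so neither going from the 3,4,5-trimethoxyphenyl to the 4-methoxyphenyl nor adding a methoxy to the plain phenyl is shown to reach beyond the scatter. These two steps remain floors, and their full size cannot be read, because compound 1 and compound 3 each stand at a limit and not at a number: the limit of > 100000 nM in this assay, at which 2 of the 4 values shown sit.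

As far as these compounds go, whether an amine or a carboxylic acid on this ring would move the number beyond the scatter stays open. So does the effect of a longer chain in place of the methoxy of the 4-methoxyphenyl.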